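The source may report more compounds than this note shows. Statements on the series, on what has been measured and on what is new or still open speak of the compounds shown alone.

Measured so far: compound 1 `Cc1ccc(C2=NN(C3=NC(=O)CS3)C(c3ccc4ccccc4c3)C2)cc1` gives 7790 nM in a functional assay on BGC-823 cells (Homo sapiens) for inhibition, read by CCK-8 assay, with a stated time of 48 h; a higher number here means a weaker inhibitor, a lower number a stronger inhibitor; compound 2 `O=C1CSC(N2N=C(c3ccc(Br)cc3)CC2c2cccc3ccccc23)=N1` gives 14600 nM; compound 3 `O=C1CSC(N2N=C(c3ccc(Cl)cc3)CC2c2ccc3ccccc3c2)=N1` gives 13200 nM.

In this assay compound 2 is separated from neither compound 3 nor compound 1 by more than the usual scatter. Compound 4 `Cc1ccc(C2=NN(C3=NC(=O)CS3)C(c3cccc4ccccc34)C2)cc1` differs from compound 2 by methyl in place of bromo on an aromatic carbon. Among the compounds with values here, the one measured step that bears on this is a 1.7-fold higher number from compound 1 to compound 3 (0.23 log units; within the scatter), a halogen-for-methyl exchange at the same kind of position that stayed within the scatter; no measured step exchanges bromo for methyl directly. Putting methyl in place of a halogen is therefore expected to move this assay little, if anything toward a somewhat lower number. Compound 4 is estimated at 10000 nM, with a range of 4500 nM to 22000 nM. The expected step, a 1.5-fold lower number from compound 2 to compound 4 (0.16 log units; within the scatter), lies within the scatter.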

Compound 4, half-maximal inhibitory concentration: 10000 nM
The estimate for compound 4 equals the measured number at the digits printed, within the range that was stated.
By their numbers in this assay, from the lowest: compounds 1, 4, 3 and 2 (each within the scatter of the next).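

In this assay, the exchange of bromo for methyl on this aromatic carbon stays within the scatter (a 1.5-fold lower number from compound 2 to compound 4 (0.16 log units; within the scatter)). This extends what the chloro and methyl pair showed (a 1.7-fold higher number from compound 1 to compound 3 (0.23 log units; within the scatter)) to a second halogen, in a pair whose remaining structure differs from that of compounds 1 and 3. No measurement shown here accounts for this result. The compounds shown leave open whether an amine or a carboxylic acid in this place would give a number beyond the scatter from methyl.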